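The source may report more compounds than this note shows. Statements on the series, on what has been measured and on what is new or still open speak of the compounds shown alone.

Measured so far in a functional assay on K562 cells (Homo sapiens), read by MTT assay, with a stated time of 72 h; on this read-out lower numbers stand for stronger inhibition and higher numbers for weaker inhibition:

Compound 1 `Cc1nc(N)c2c(-c3ccccc3)cn([C@@H]3O[C@H](CO)[C@@H](O)[C@H]3O)c2n1`: compound 1 gives > 20000 nM, which is a limit of this assay and not a number.
Compound 2 `Cc1nc(N)c2c(-c3cccs3)cn([C@@H]3O[C@H](CO)[C@@H](O)[C@H]3O)c2n1`: compound 2 gives > 20000 nM, also a limit of this assay.
Compound 3 `COc1ncnc2c1c(-c1cccs1)cn2[C@@H]1O[C@H](CO)[C@@H](O)[C@H]1O`: compound 3 gives 6200 nM.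

Compound 3 is the only one of the three with a number in this assay; the other two values sit at the limit (the limit of > 20000 nM in this assay, at which 2 of the 3 values shown sit). The cores of compound 2 and compound 3 differ, but the difference between the two cores is not broken down here.

One change recurs. From compound 2 to compound 1 it is phenyl in place of thiophen-2-yl on an aromatic carbon; the step that the two limits leave unreadable from compound 2 to compound 1 cannot be read because both ends sit at the limit (the limit of > 20000 nM in this assay, at which 2 of the 3 values shown sit).

Not yet measured is compound 4 `COc1ncnc2c1c(-c1ccccc1)cn2[C@@H]1O[C@H](CO)[C@@H](O)[C@H]1O`, reached from compound 3 by phenyl in place of thiophen-2-yl on an aromatic carbon, the same change at the same place. Since the measured pair gives no readable size for it, the expected step of a 1.3-fold higher number from compound 3 to compound 4 (0.11 log units; within the scatter) in this assay rests only on the value of compound 3 and on the scatter of this kind of measurement. Compound 4 is therefore estimated at 8000 nM, with a range from 2500 nM to 25000 nM.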

Compound 4, half-maximal inhibitory concentration: > 20000 nM
Compound 4: no number, only a limit (the forecaster's own chance of this, stated with the estimate: 30%); at least 2.5-fold (0.39 log units) between middle value and limit.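

In this assay, phenyl in place of thiophen-2-yl on the core of compound 3 gives an at least 3.2-fold higher number from compound 3 to compound 4 (0.50 log units; beyond the scatter), so this change carries a readable loss on this one core. Compound 4 gives > 20000 nM, which is a limit of the assay and not a number. The step from compound 2 to compound 1 cannot be read, so the data neither support nor contradict the same change acting alike on both cores, and the readable size belongs to the core of compound 3 alone, with most of the values shown sitting at one ceiling: the limit of > 20000 nM in this assay, at which 3 of the 4 values shown sit.

Open, as far as these compounds go, is how a carboxylic acid, a dimethylamino group or a longer alkyl chain in place of thiophen-2-yl would read in this assay. Also open, from the compounds shown here alone, is whether any group at this place brings the core of compound 2 to a number, which would be needed before the step could be compared across the two cores.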